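The source may report more compounds than this note shows. Statements on the series, on what has been measured and on what is new or still open speak of the compounds shown alone.

Working notes on the series around compound 1 `Cc1cccc2c1N(CC(=O)O)C/C(=C\c1ccccc1Cl)C2=O`. Among the measured compounds shown here, in an assay on HL-60 cells for inhibition of glutathione S-transferase P (Homo sapiens), read by spectrophotometry, tested at 20 uM (a lower number here means less inhibition, a higher number more inhibition at the concentration tested (going by the name of the read-out)), compound 1 gives 51.9%, the highest of the three numbers so far. Compound 2 `CCOc1ccc(/C=C2\CN(CC(=O)O)c3ccc(C)cc3C2=O)cc1` gives 25.8% in this assay, and compound 3 `CCOc1ccccc1/C=C1\CN(CC(=O)O)c2c(C)cccc2C1=O` gives 15.4%; both lie under compound 1 by more than the scatter. For the measured compounds named here, the one single-point step inside the measured set is a number 36.5 percentage points lower from compound 1 to compound 3 (beyond the scatter), a large loss.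

Compound 4 `Cc1ccc(/C=C2\CN(CC(=O)O)c3c(C)cccc3C2=O)cc1` is still to be measured. It differs from compound 1 in one place: 4-methylphenyl in place of 2-chlorophenyl on a double-bonded chain carbon bound to a double-bonded ring carbon. Going by the values given here, the only measured step that touches the same aromatic ring is a number 36.5 percentage points lower from compound 1 to compound 3 (beyond the scatter), and it bears on the new step only loosely, since methyl is not ethoxy and sits at another position of that ring. Among the compounds with values here, no step with a methyl there has been measured. The expectation is a loss smaller than that seen with ethoxy, a number 16.9 percentage points lower from compound 1 to compound 4 (beyond the scatter), in this assay. Compound 4 is therefore estimated at 35%, with a range from 15% to 55%.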

Compound 4, a percentage reported as inhibition, at one concentration (the size of the read-out at that concentration, not a potency): 46.8%
For compound 4 the middle estimate is 11.8 percentage points below the measured one; the measured number falls inside the stated range.
By their numbers in this assay, from the lowest: compound 3; then compound 2; then compounds 4 and 1 (each within the scatter of the next).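

In this assay, 4-methylphenyl in place of 2-chlorophenyl gives a number 5.1 percentage points lower from compound 1 to compound 4 (within the scatter), so on this double-bonded chain carbon bound to a double-bonded ring carbon, the chlorine is not needed to hold the read-out at the concentration tested. The earlier a number 36.5 percentage points lower from compound 1 to compound 3 (beyond the scatter) alone left open that any departure from 2-chlorophenyl would cost inhibition, and compound 4 shows that at least one replacement does not. Nothing measured bears on why these two replacements differ in outcome.

The change from compound 1 to compound 4 alters both the group and its place on the aromatic ring, so the two contributions cannot be separated. Also open, as far as these compounds go, is whether an unsubstituted phenyl, a hydroxyl or an amine on that ring would stay within the scatter of compound 1.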